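Cytotoxicity in Vero Cells from Compound 3 to Compound 4

The source may report more compounds than this note shows. Statements on the series, on what has been measured and on what is new or still open speak of the compounds shown alone.

Of the compounds shown here, three have been measured in an ADME assay on Vero cells (Chlorocebus sabaeus) for cytotoxicity, read by MTT assay, with a stated time of 72 h; on this read-out higher numbers stand for weaker inhibition and lower numbers for stronger inhibition. Compound 1 `O=[N+]([O-])c1c[nH]c(-c2nnc(-c3cccs3)o2)c1` gives 418000 nM in this assay. Compound 2 `Cn1cc([N+](=O)[O-])cc1-c1nnc(-c2ccccc2Br)o1` gives 303000 nM in this assay, and compound 3 `Cn1cc([N+](=O)[O-])cc1-c1nnc(-c2ccns2)o1` gives 320000 nM in this assay. Among these three numbers compound 3 stands second highest; its nearest neighbour is compound 2, and the single measured step, a 1.1-fold higher number from compound 2 to compound 3 (0.02 log units; within the scatter), lies within the scatter, while the gap between compound 3 and compound 1 is also within the scatter.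

Compound 4 `Cn1cc([N+](=O)[O-])cc1-c1nnc(-c2cccs2)o1` differs from compound 3 in one place: thiophen-2-yl in place of 1,2-thiazol-5-yl on an aromatic carbon. Among the compounds with values here, no measured step covers this exchange directly. Within the data shown here, the one step available replaced a different group on the same aromatic carbon and stayed within the scatter, and compound 1, which already carries thiophen-2-yl on that carbon, gives a number within the scatter of compound 3. On this basis the expected change from compound 3 to compound 4 in this assay is a 1.1-fold higher number from compound 3 to compound 4 (0.03 log units; within the scatter), none beyond the scatter. Compound 4 is therefore estimated at 340000 nM in this assay, with a range from 200000 nM to 600000 nM.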

Compound 4, half-maximal inhibitory concentration: 521000 nM
Compound 4: the middle estimate sits 1.5-fold (0.19 log units) below what was measured, and the stated range covers the measured number.
By their numbers in this assay, from the lowest: compounds 2, 3, 1 and 4 (each within the scatter of the next).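

In this assay, the exchange on this aromatic carbon can now be read directly: thiophen-2-yl in place of 1,2-thiazol-5-yl gives a 1.6-fold higher number from compound 3 to compound 4 (0.21 log units; within the scatter), and thiophen-2-yl in place of 2-bromophenyl gives a 1.7-fold higher number from compound 2 to compound 4 (0.24 log units; within the scatter), so all three aromatic groups compared at this carbon, with methyl held on the aromatic nitrogen, lie within the scatter of one another. The result also opens a second position, since with thiophen-2-yl held in place, methyl in place of hydrogen on an aromatic nitrogen gives a 1.2-fold higher number from compound 1 to compound 4 (0.10 log units; within the scatter), and this change too stays within the scatter. No separate measurement bears on these results, and the compounds themselves offer no account of them.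

All the groups shown at this carbon are aromatic rings, so it remains open whether an amine, a carboxylic acid or a longer alkyl chain there would give a number beyond the scatter. The nitro group on the shared core is present in all four compounds, which leaves open what a nitrile or an amide in its place would do.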